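The compounds below may be only part of what the source reports. "The series", "measured", "known", "first", "only" and "open" are said of these compounds alone.

Measured compounds in a functional assay on RPMI-8226 cells (Homo sapiens) for inhibition; on this read-out higher numbers stand for weaker inhibition and lower numbers for stronger inhibition:
- compound 1 `CCOC(=O)c1ccc(NC(=O)N2CC2C#N)cc1`: 3000 nM
- compound 2 `N#CC1CN1C(=O)Nc1ccccc1`: 8000 nM

Compound 2 gives the highest of the two numbers in this assay, meaning the weaker inhibition of the pair. Among the compounds with values here, the only measured step is a 2.7-fold higher number from compound 1 to compound 2 (0.43 log units; beyond the scatter), where an ethoxycarbonyl group is replaced by hydrogen on an aromatic carbon, and it made inhibition modestly weaker. Compound 3 `CC(=O)c1cccc(NC(=O)N2CC2C#N)c1` differs from compound 2 by acetyl in place of hydrogen on an aromatic carbon. Within the data shown here, this reintroduces a carbonyl-bearing substituent on the ring, though a smaller one and at a different aromatic carbon than in compound 1, so only the step of a 2.7-fold higher number from compound 1 to compound 2 (0.43 log units; beyond the scatter) bears on it, and only loosely. A return toward the number of compound 1 is therefore expected, of roughly similar size but less certain. The estimated step is a 2.0-fold lower number from compound 2 to compound 3 (0.30 log units; within the scatter), giving an expected value for compound 3 of 4000 nM, within a range of 1500 nM to 10000 nM.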

Compound 3, half-maximal inhibitory concentration: 9600 nM
Beside the measured number, compound 3's estimate is 2.4-fold (0.38 log units) below it, within the range that was stated.
By their numbers in this assay, from the lowest: compound 1; then compounds 2 and 3 (each within the scatter of the next).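

In this assay, placing acetyl on an aromatic carbon, meta to a group of 8 heavy atoms, gives a 1.2-fold higher number from compound 2 to compound 3 (0.08 log units; within the scatter) and so leaves inhibition within the usual scatter of the ring that carries only hydrogen. A carbonyl-bearing group on the ring is therefore not enough on its own to produce a step like a 2.7-fold higher number from compound 1 to compound 2 (0.43 log units; beyond the scatter) in this pair, where ethoxycarbonyl is the group that changes. No measurement here offers an explanation for this result.

Ethoxycarbonyl and acetyl differ both as groups and in where they sit on the ring, so the compounds shown cannot separate the effect of the group from that of its place. On these data alone, it also remains open whether an amine or a carboxylic acid on this same ring carbon would move the number beyond the scatter.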